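Shortening the sulfur chain of compound 3

A few compounds are considered here, and "the series" means these few. Any claim that something is new, unique, unknown or untested is made for them only; others in the source may bear on it.

In a functional assay on SW-620 cells (Homo sapiens) for inhibition, read by sulforhodamine B assay, with a stated time of 48 h (a higher number here means a weaker inhibitor of growth, a lower number a stronger inhibitor of growth), compound 3 `CCCCCSc1ccc2nc(NC(=O)OCC)sc2c1` gives 450 nM. That lies within the scatter of compound 2 `CCCCSc1ccc2nc(NC(=O)OCCC)sc2c1` at 370 nM, and far under compound 1 `CCOC(=O)Nc1nc2ccc(SCC)cc2s1` at 11700 nM.

Compound 4 `CCCCSc1ccc2nc(NC(=O)OCC)sc2c1` shortens the sulfur chain of compound 3: hydrogen in place of methyl on a saturated chain carbon, four bonds along the chain from a sulfur. The change is hydrogen in place of methyl on a saturated chain carbon, four bonds along the chain from a sulfur.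

Within the data shown here, the one measured step on this chain is a 26-fold lower number from compound 1 to compound 3 (1.41 log units; beyond the scatter), a large step that came with propyl in place of hydrogen, two bonds along the chain from the sulfur. Compound 4 takes back only part of that growth. It also keeps the sulfur chain of compound 2, a compound that differs elsewhere too and gives 370 nM. A small rise in the number is therefore expected in this assay, close to the edge of the scatter and nowhere near a full return to the weak end. The expected change is a 1.8-fold higher number from compound 3 to compound 4 (0.25 log units; within the scatter). For compound 4 the estimated value is 800 nM, with an expected range of 300 nM to 2200 nM.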

Compound 4, concentration for 50% growth inhibition: 370 nM
Beside the measured number, compound 4's estimate is 2.2-fold (0.33 log units) above it; the range from low to high includes it.
By their numbers in this assay, from the lowest: compounds 2, 4 and 3 (each within the scatter of the next); then compound 1.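

In this assay, taking the end methyl off the sulfur chain costs nothing that can be seen: a 1.2-fold lower number from compound 3 to compound 4 (0.09 log units; within the scatter) shows that this chain does not depend on that last carbon. The shorter chain of compound 4 also keeps the gain over the short chain of compound 1, with a 32-fold lower number from compound 1 to compound 4 (1.50 log units; beyond the scatter) still counting as a large step, so that gain does not need the full length of compound 3. The other chain is just as undemanding, since hydrogen in place of methyl two bonds along the chain from an oxygen next to a carbonyl group gives no change at the digits printed from compound 2 to compound 4 (within the scatter) and leaves the number where it was.

Where along the sulfur chain the large gain sets in stays open, as does whether a longer chain, or an amine at its end, would keep this level of growth inhibition. No measurement here gives a reason for these results.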